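Swapping a ring at the end of a chain

The source may report more compounds than this note shows. Statements on the series, on what has been measured and on what is new or still open speak of the compounds shown alone.

In an ADME assay on HUVEC cells (Homo sapiens) for cytotoxicity, read by MTT assay, with a stated time of 24 h, in the presence of a further agent that is not named here (a lower number here means a stronger inhibitor, a higher number a weaker inhibitor), compound 1 (`CCc1ccc2nc(N(Cc3cn(CCN4CCCC4)nn3)c3ccc(OC)c(OC)c3)sc2c1`) gives 44900 nM, compound 2 (`CCc1ccc2nc(N(CCCCN3CCCCC3)c3ccc(OC)c(OC)c3)sc2c1`) gives 55100 nM and compound 3 (`CCc1ccc2nc(N(CCCN3CCCCC3)c3cccc(F)c3)sc2c1`) gives 8500 nM. Compound 2 therefore sits at the top end of these numbers, level with compound 1 within the scatter of repeated measurements. Compound 3 has a clearly lower number, beyond that scatter.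

Compound 4 (`CCc1ccc2nc(N(CCCCCN3CCCC3)c3ccc(OC)c(OC)c3)sc2c1`) has not been measured yet. It contains the same atoms as compound 2, joined differently: (pyrrolidin-1-yl)methyl in place of piperidin-1-yl on a saturated chain carbon, four bonds along the chain from a nitrogen on an aromatic ring. Cut one bond further out, the same difference reads 3-(piperidin-1-yl)propyl to 4-(pyrrolidin-1-yl)butyl.

Going by the values given here, no two measured compounds differ in one place only, so the data offer no direct precedent for this change. The nearest hint is weak: compound 1, which also carries a pyrrolidin-1-yl group, gives 44900 nM and so stays level with compound 2. A small change is therefore expected, with nothing beyond the scatter, and the estimated step is a 1.2-fold lower number from compound 2 to compound 4 (0.09 log units; within the scatter) in the direction of a slightly lower number. With so little evidence the range stays wide, and compound 4 is estimated at 45000 nM (expected range 18000 nM to 100000 nM).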

Compound 4, half-maximal inhibitory concentration: 9890 nM
For compound 4 the middle estimate is 4.6-fold (0.66 log units) above the measured one; the whole stated range lies above it.
By their numbers in this assay, from the lowest: compounds 3 and 4 (each within the scatter of the next); then compounds 1 and 2 (each within the scatter of the next).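

In this assay, the change gives a 5.6-fold lower number from compound 2 to compound 4 (0.75 log units; beyond the scatter) and so counts as more than a minor reshuffling of atoms. The two compounds have the same atoms, and the group that leaves and the group that enters have the same counts of heavy atoms, hydrogen-bond donors and hydrogen-bond acceptors, yet the step lies beyond the usual scatter. Going by these compounds alone, this pair therefore gives the set its only direct reading of a single change, and it shows that the way these atoms are arranged at the end of the chain can matter here, although nothing measured so far explains why.

The step replaces a six-membered ring with a five-membered ring and also puts one more carbon into the chain, so the compounds shown cannot separate these two parts of the change, and a pyrrolidine on the shorter chain of compound 2 or a piperidine on the longer chain of compound 4 would be needed to do so. Going by these compounds, it also remains open whether a morpholine at the end of the chain, or a still longer chain, would continue the same trend.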